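Ester for ketone on the aryl of compound 1

The compounds below may be only part of what the source reports. "The series", "measured", "known", "first", "only" and "open" are said of these compounds alone.

Going by the values given here, compound 1 `COc1cc(-c2ccnc3cc(-c4ccc(C(C)=O)cc4)nn23)cc(OC)c1OC` is the weakest of the three measured members: in a functional assay on B16-F0 cells (Mus musculus) for inhibition, read by CCK-8 assay, with a stated time of 48 h (a lower number here means a stronger inhibitor, a higher number a weaker inhibitor), compound 1 gives 3930 nM. Compound 2 `COc1cc(-c2ccnc3cc(-c4c[nH]c5ccccc45)nn23)cc(OC)c1OC` gives 40 nM in this assay, and compound 3 `COc1cc(-c2ccnc3cc(-c4ccc5ccn(C)c5c4)nn23)cc(OC)c1OC` gives 657 nM. The measured steps all exchange the whole aryl group on the shared core: a 98-fold lower number from compound 1 to compound 2 (1.99 log units; beyond the scatter), a 6.0-fold lower number from compound 1 to compound 3 (0.78 log units; beyond the scatter) and a 16-fold higher number from compound 2 to compound 3 (1.22 log units; beyond the scatter). Compound 4 `CCOC(=O)c1ccc(-c2cc3nccc(-c4cc(OC)c(OC)c(OC)c4)n3n2)cc1` keeps the aryl of compound 1 and alters only its substituent: ethoxy in place of methyl on a carbonyl carbon. Among the compounds with values here, no measured step touches the acetyl group itself, so none of them bears directly on this change; the series gives no evidence for either direction here. The expectation is therefore a step within the usual scatter, a 1.0-fold higher number from compound 1 to compound 4 (0.01 log units; within the scatter), with compound 4 remaining near compound 1. Compound 4 is estimated at 4000 nM in this assay, within a range of 1300 nM to 12000 nM.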

Compound 4, half-maximal inhibitory concentration: > 10000 nM
Compound 4: only a limit was reported; the forecaster's own chance of this, stated with the estimate: 10%; middle value at least 2.5-fold (0.39 log units) away from the limit.
By their numbers in this assay, from the lowest: compound 2; then compound 3; then compound 1. At a limit, above all of these: compound 4.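

In this assay compound 4 gives > 10000 nM, which is a limit of the assay and not a number. Ethoxy in place of methyl on a carbonyl carbon gives an at least 2.5-fold higher number from compound 1 to compound 4 (0.40 log units; beyond the scatter), so a change confined to the substituent on this carbonyl carbon, with the aryl group kept, moves the result beyond the scatter, which the earlier steps, all exchanges of the whole aryl group, could not show. The reading of this step rests on a single limit: the limit of > 10000 nM in this assay, at which 1 of the 4 values shown sits.

Going by these compounds, how far compound 4 lies past its limit stays open, so the step has a lower bound and no size. Also open, on these data alone, is whether a methyl ester, a carboxylic acid or a primary amide on the same carbonyl carbon would read like compound 1 or like compound 4.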